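Swapping thiophen-2-yl for 4-fluorophenyl on a carbonyl carbon

The source may report more compounds than this note shows. Statements on the series, on what has been measured and on what is new or still open speak of the compounds shown alone.

Of the compounds shown here, three have numbers so far in a functional assay on HepG2 cells (Homo sapiens) for inhibition, read by MTT assay, with a stated time of 48 h; on this read-out lower numbers stand for stronger inhibition and higher numbers for weaker inhibition. Compound 1 (`COc1ccc(-c2nc3c(c(-c4ccccc4)nn3-c3ccccc3)c(-c3ccc(N4CCCCC4)cc3)c2C#N)cc1`) gives 12500 nM as its half-maximal concentration. Compound 2 (`O=C(C=CNc1cc(-c2ccccc2)nn1-c1ccccc1)c1cccs1`) gives 2420 nM on the same scale, and compound 3 (`Fc1ccc(-c2ccnc3c2c(-c2ccccc2)nn3-c2ccccc2)cc1`) gives 1570 nM there. Compound 2 therefore sits within the usual scatter of compound 3, while compound 1 has a clearly higher number, which means weaker inhibition.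

The next compound to be measured is compound 4 (`O=C(C=CNc1cc(-c2ccccc2)nn1-c1ccccc1)c1ccc(F)cc1`). It differs from compound 2 in one place (4-fluorophenyl in place of thiophen-2-yl on a carbonyl carbon), with 4-fluorophenyl in place of thiophen-2-yl on a carbonyl carbon. Among the measured compounds shown here, no measured pair shows this swap, so there is no direct precedent for its size. One aromatic ring replaces another, and compound 3, which also carries a 4-fluorophenyl group, gives 1570 nM in this assay despite its different core. The expected step of a 1.2-fold lower number from compound 2 to compound 4 (0.08 log units; within the scatter) is slightly downward and stays within the scatter. The estimate for compound 4 is 2000 nM as a middle value, with 750 nM to 5500 nM as the expected range.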

Compound 4, half-maximal inhibitory concentration: 59900 nM
Compound 4: middle estimate off by 30-fold (1.48 log units), on the low side; the whole stated range lies below it.
By their numbers in this assay, from the lowest: compounds 3 and 2 (each within the scatter of the next); then compound 1; then compound 4.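

In this assay the group on the carbonyl carbon turns out to matter a great deal: with the rest of the molecule unchanged, putting 4-fluorophenyl in place of thiophen-2-yl gives a 25-fold higher number from compound 2 to compound 4 (1.39 log units; beyond the scatter) and so much weaker inhibition. Among the compounds shown here, one aromatic ring therefore cannot be assumed to stand in for another at this place, which the earlier compounds could not show, as no two of them differed in one place only. Nothing available here explains why this step is so large.

Going by these compounds, it remains open whether the fluorine or the six-membered ring accounts for the step, a question that a plain phenyl on the same carbonyl carbon would help to settle. Also open, on these data alone, is how a furan-2-yl or a short alkyl chain would read at this place.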